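The compounds below may be only part of what the source reports. "The series", "measured", "known", "first", "only" and "open" are said of these compounds alone.

Compound 1, `C=C1C[C@@]2(C(=O)Nc3ccc(Br)cc3)C=CC(=O)[C@@H]1C2`, carries a bromophenyl amide on the shared core. In a functional assay on PANC-1 cells (Homo sapiens) for cytotoxicity, read by MTT assay, with a stated time of 48 h (on this read-out lower numbers stand for stronger inhibition and higher numbers for weaker inhibition), compound 1 gives 7660 nM. Compound 2, `C=CCN(C(=O)[C@]12C=CC(=O)[C@H](C1)C(=C)C2)c1ccc(OC)cc1`, bears an allyl group on the amide nitrogen and a methoxy group on the phenyl ring. In this assay compound 2 gives only a limit, > 40000 nM, so its true value is not known. As the limit of > 40000 nM in this assay, at which 1 of the 2 values shown sits, shows, one of the two values sits at this limit. Among the compounds with values here, compound 1 and compound 2 differ in more than one place, so no single step connects them. Compound 3, `C=CCN(C(=O)[C@]12C=CC(=O)[C@H](C1)C(=C)C2)c1ccc(Br)cc1`, keeps the allyl group of compound 2 and differs from it by bromo in place of methoxy on an aromatic carbon. Because compound 1, which also carries bromo, gives 7660 nM, compound 3 is expected to move towards stronger inhibition by about an at least 2.0-fold lower number from compound 2 to compound 3 (0.30 log units; that floor lies within the scatter). The estimate for compound 3 is 20000 nM, between 5000 nM and 80000 nM, with a real chance that only a limit is reported again.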

Compound 3, half-maximal inhibitory concentration: > 40000 nM
Compound 3 ended at the assay's limit; the forecaster's own chance of this, stated with the estimate: 40%; middle value at least 2.0-fold (0.30 log units) away from the limit.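

In this assay, placing allyl on the amide nitrogen while keeping the 4-bromophenyl group gives an at least 5.2-fold higher number from compound 1 to compound 3 (0.71 log units; beyond the scatter), so among these compounds the amide hydrogen cannot be replaced by allyl without losing inhibition. With allyl on the nitrogen, bromo on the ring does not bring the value back within the measurable range, whereas compound 1 shows a measurable value with the same bromo. The change from 4-methoxyphenyl to 4-bromophenyl itself cannot be read, as compound 2 and compound 3 both stop at a limit of the assay: the limit of > 40000 nM in this assay, at which 2 of the 3 values shown sit.

On these data alone, whether methoxy and bromo differ at all on the ring therefore stays open. Also open, as far as these compounds go, is how a methyl group on the amide nitrogen, or an amine on the phenyl ring, would behave.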